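The source may report more compounds than this note shows. Statements on the series, on what has been measured and on what is new or still open speak of the compounds shown alone.

Of the compounds shown here, two sharing one core have been tested so far in a functional assay on HeLa cells (Homo sapiens) for antiproliferative activity, read by MTT assay, with a stated time of 48 h; a higher number here means a weaker inhibitor, a lower number a stronger inhibitor. There, compound 1 `COc1ccc(C(=O)c2ccc(OC)c3c2OC(C)(C)C=C3)c(NC(=O)CO)c1` gives 100 nM and compound 2 `CNCC(=O)Nc1cc(OC)ccc1C(=O)c1ccc(OC)c2c1OC(C)(C)C=C2` gives 870 nM, the higher of the two numbers, which makes compound 2 the weaker inhibitor of this pair.

Compound 3 `CCNCC(=O)Nc1cc(OC)ccc1C(=O)c1ccc(OC)c2c1OC(C)(C)C=C2` has not yet been measured. It differs from compound 2 by one small change: methyl in place of hydrogen on a saturated chain carbon bound to an amine nitrogen. This is methyl in place of hydrogen on a saturated chain carbon bound to an amine nitrogen, so methylamino becomes ethylamino.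

Among the measured compounds shown here, only one measured step is available for comparison, an 8.7-fold higher number from compound 1 to compound 2 (0.94 log units; beyond the scatter), and it is modest but beyond the scatter. That step put methylamino in place of hydroxy, a different exchange from this one, so it is only a loose guide. For the measured compounds named here, no measured step adds a methyl group, and the data give no direction for this change. The expected step in this assay is therefore a 1.0-fold higher number from compound 2 to compound 3 (0.01 log units; within the scatter), an estimate that stays within the scatter. For compound 3 the estimated value is 900 nM, with an expected range from 350 nM to 2300 nM.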

Compound 3, half-maximal inhibitory concentration: 2690 nM
The estimate for compound 3 lay 3.0-fold (0.48 log units) below the measured number, and the stated range ends below it.
By their numbers in this assay, from the lowest: compound 1; then compound 2; then compound 3.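

In this assay, this position proves sensitive to even the smallest extension of the chain: methyl in place of hydrogen on the saturated chain carbon bound to the amine nitrogen, which turns methylamino into ethylamino, gives a 3.1-fold higher number from compound 2 to compound 3 (0.49 log units; beyond the scatter) and so goes beyond the scatter. The earlier compounds shown here showed only that exchanging hydroxy for methylamino raised the number, whereas this step shows that the number can also differ between two amines that are one carbon apart, and ethylamino in place of hydroxy adds up to a 27-fold higher number from compound 1 to compound 3 (1.43 log units; beyond the scatter) in all. Among these three compounds the number rises from hydroxy to methylamino to ethylamino, but no measurement shown here gives a reason for that order.

Going by these compounds, whether the number would keep rising with a longer chain such as propylamino, or with a branched one such as isopropylamino, remains open. Also open, on these data alone, is where a plain amino group, with no carbon on its nitrogen, or a ring amine such as morpholine would fall relative to hydroxy and the two amines already tested.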